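The compounds below may be only part of what the source reports. "The series", "measured", "known", "first", "only" and "open" are said of these compounds alone.

Compound 1 `CCOC(=O)c1csc(-c2nc3ccccc3n2C)n1` was tested in a functional assay on MCF7 cells (Homo sapiens) for cytotoxicity, read by MTT assay, with a stated time of 24 h; on this read-out lower numbers stand for stronger inhibition and higher numbers for weaker inhibition. In this assay compound 1 gives > 20000 nM, which is a limit of the assay rather than a number. For the measured compounds named here, compound 2 `CCOC(=O)c1csc(-c2nc3ccccc3n2CC)n1` is the only other compound measured. In this assay compound 2 gives > 20000 nM, again only a limit. Going by the values given here, both values sit at the limit of > 20000 nM in this assay, at which 2 of the 2 values shown sit, so the one measured step, a step that the two limits leave unreadable from compound 1 to compound 2, cannot be read. Compound 3 `CCOC(=O)Cc1csc(-c2nc3ccccc3n2C)n1` differs from compound 1 by (ethoxycarbonyl)methyl in place of ethoxycarbonyl on an aromatic carbon. No readable step bears on this change, so the expected step is a step that the limit leaves unreadable from compound 1 to compound 3. Compound 3 is estimated at 30000 nM. For compound 3 the expected range runs from 10000 nM to 100000 nM, most likely reported again as a limit.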

Compound 3, half-maximal inhibitory concentration: > 20000 nM
Compound 3: a limit, no number; the forecaster's own chance of this, stated with the estimate: 85%; the middle value does not contradict the limit.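

Compound 1 and compound 3 both stop at a limit rather than a number, so the step between them cannot be read: the limit of > 20000 nM in this assay, at which 3 of the 3 values shown sit.

The compounds shown leave open what concentration, if any, gives half-maximal inhibition in this assay, and whether either change matters at all.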